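The source may hold more compounds than are shown below. What is called first, only, known or untested is meant among the compounds shown, and "the series" means these compounds.

Compound 1 `Cn1nc(-c2ccccc2)c2cc(C(=N)Nc3cccc(C(F)(F)F)c3)ncc21`: 21400 nM in a functional assay on MDA-MB-231 cells (Homo sapiens) for cytotoxicity, read by MTT assay, with a stated time of 72 h; a lower number here means a stronger inhibitor, a higher number a weaker inhibitor.
Compound 2 `COc1ccc(Cn2nc(-c3ccccc3)c3cc(C(=N)Nc4cccc(C(F)(F)F)c4)ncc32)cc1`: a limit of this assay, > 50000 nM.
Compound 3 `Cn1cc2cc(C(=N)Nc3ccccc3)ncc2n1`: a limit of this assay, > 50000 nM.

The change from compound 1 to compound 2 is 4-methoxyphenyl in place of hydrogen on a saturated chain carbon bound to an aromatic nitrogen; it gives an at least 2.3-fold higher number from compound 1 to compound 2 (0.36 log units; beyond the scatter), reaching (the limit of > 50000 nM in this assay, at which 2 of the 3 values shown sit). Compound 4 `COc1ccc(Cn2cc3cc(C(=N)Nc4ccccc4)ncc3n2)cc1` is not yet measured; it carries the same change on the core of compound 3, (4-methoxyphenyl in place of hydrogen on a saturated chain carbon bound to an aromatic nitrogen). The difference between the two cores is not broken down here.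

Compound 3 already sits at a limit in this assay, and the same change in the measured pair weakened inhibition in an at least 2.3-fold higher number from compound 1 to compound 2 (0.36 log units; beyond the scatter), so compound 4 is expected to remain at or beyond the limit, with an estimated step that the limit leaves unreadable from compound 3 to compound 4. Compound 4 is therefore estimated at 100000 nM, expected between 50000 nM and 300000 nM.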

Compound 4, half-maximal inhibitory concentration: 1520 nM
Compound 4: the middle estimate sits 66-fold (1.82 log units) above what was measured; measured number below the stated range.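

In this assay the change gives an at least 32-fold lower number from compound 3 to compound 4 (1.51 log units; beyond the scatter), so its effect on the core of compound 1 did not carry over to the core of compound 3, and the two steps run in opposite directions: the same change on two cores in this assay, an at least 2.3-fold higher number (0.36 log units; beyond the scatter) from compound 1 to compound 2 and an at least 32-fold lower number (1.51 log units; beyond the scatter) from compound 3 to compound 4, at least 76-fold (1.88 log units) apart, beyond the scatter of two such steps

Each step has one end at a limit of the assay, so both sizes are minimum sizes only: the limit of > 50000 nM in this assay, at which 2 of the 4 values shown sit.

The result shows that the effect of this change depends on the core in this pair of cores, but not which part of the difference between them is responsible.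

Open, as far as these compounds go, is whether the gain on the core of compound 3 is specific to 4-methoxybenzyl or would also appear with plain benzyl, a longer chain or a chain ending in an amine. Also open, from the compounds shown here alone, is whether the phenyl or the trifluoromethyl of compound 1, each taken alone, would reverse the step.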